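The source may report more compounds than this note shows. Statements on the series, on what has been measured and on what is new or still open speak of the compounds shown alone.

Compound 1 `O=C(O)C[C@@H]1CCCN1c1ccc(Oc2ccccc2)cc1` carries an unsubstituted phenyl on the ether oxygen. In a functional assay on cells for agonist activity at Free fatty acid receptor 1 (Mus musculus), read by FLIPR and calcium flux, with a stated time of 100 s (a lower number here means that less compound is needed, a higher number that more compound is needed for the effect), compound 1 gives only a limit, > 16000 nM, and no number. Of the three values recorded, one is a number and two are limits, so compound 1 sits at the weak end of what this assay resolves. Going by the values given here, compound 2 `O=C(O)C[C@@H]1CCCN1c1ccc(Oc2ccc(Cl)cc2Cl)cc1` is the only compound returning a number: in this assay compound 2 gives 3200 nM. The change 2,4-dichlorophenyl in place of phenyl on the oxygen gives an at least 5.0-fold lower number from compound 1 to compound 2 (0.69 log units; beyond the scatter). Compound 3 `CC(C)(C)c1ccccc1Oc1ccc(N2CCC[C@H]2CC(=O)O)cc1` adds a tert-butyl on an aromatic carbon of that phenyl. In this assay compound 3 gives a limit, > 17000 nM, rather than a number. The step that the two limits leave unreadable from compound 1 to compound 3 cannot be read because the limit of > 16000 nM in this assay, at which 1 of the 3 values shown sits, and the limit of > 17000 nM in this assay, at which 1 of the 3 values shown sits, both cap what can be seen.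

Compound 4 `CN(C)c1cccc(Oc2ccc(N3CCC[C@H]3CC(=O)O)cc2)c1` differs from compound 1 by dimethylamino in place of hydrogen on an aromatic carbon. Among the compounds with values here, the only readable step on substitution of this ring is the dichloro step from compound 1 to compound 2, which brought compound 2 into the measurable range; the tert-butyl step left compound 3 at its limit. Dimethylamino enters as a single group where two chlorines were needed before a number appeared, so for compound 4 the expected step is an at least 1.3-fold lower number from compound 1 to compound 4 (0.12 log units; that floor lies within the scatter), small and possibly not reaching a number. Compound 4 is therefore estimated at 12000 nM, ranging from 4000 nM to 40000 nM, with a fair chance that only a limit is reported.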

Compound 4, half-maximal effective concentration: > 33000 nM
Compound 4: only a limit was reported; the forecaster's own chance of this, stated with the estimate: 55%; at least 2.7-fold (0.43 log units) between middle value and limit.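

In this assay compound 4 gives > 33000 nM, which is a limit and not a number. Compound 1 also stands at a limit, so no step can be read from compound 1 to compound 4. The compounds shown leave open whether dimethylamino in place of hydrogen on this ring changes the value at all.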